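A few compounds are considered here, and "the series" means these few. Any claim that something is new, unique, unknown or untested is made for them only; others in the source may bear on it.

Measured in an assay on CHO-TREX cells for antagonist activity at transient receptor potential cation channel subfamily A member 1 (Homo sapiens), read by FLIPR and calcium flux, with a stated time of 10 min; on this read-out lower numbers stand for stronger inhibition and higher numbers for weaker inhibition:
Compound 1 `CCc1ccccc1-c1ccc2[nH]ncc2c1` — 584 nM
Compound 2 `Fc1ccc(C(F)(F)F)c(-c2ccc3[nH]ncc3c2)c1` — 306 nM
Compound 3 `Fc1cc2[nH]ncc2cc1-c1ccccc1C(F)(F)F` — 48 nM

Compound 3 holds the lowest number of the three. The gap to compound 2 and the wider gap to compound 1 both lie beyond the usual scatter of this read-out, so compound 3 counts as the most potent of the measured set. No two of these three compounds differ in one place only, so none of the gaps can be tied to a single change; compound 3 carries a fluoro on the shared core together with a trifluoromethyl, and the other two compounds depart from it in more than one respect.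

Compound 4 `CCOc1cc2[nH]ncc2cc1-c1ccccc1C(F)(F)F` is the next member and is not yet measured. Relative to compound 3 the change is ethoxy in place of fluoro on an aromatic carbon. Among the measured compounds shown here, the set gives no precedent for this exchange: nothing measured sets fluoro against ethoxy at that place on the core. The expectation for the step in this assay is therefore loose: a modest shift at most, somewhat more likely toward a higher number than a lower one, with a result inside the scatter of compound 3 also plausible. The expected step is a 2.1-fold higher number from compound 3 to compound 4 (0.32 log units; beyond the scatter). Compound 4 is estimated at 100 nM in this assay, with a range from 30 nM to 350 nM.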

Compound 4, half-maximal inhibitory concentration: 39 nM
The estimate for compound 4 lay 2.6-fold (0.41 log units) above the measured number, and the stated range covers the measured number.
By their numbers in this assay, from the lowest: compounds 4 and 3 (each within the scatter of the next); then compounds 2 and 1 (each within the scatter of the next).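

In this assay, among the compounds shown here, the exchange of fluoro for ethoxy on this aromatic carbon, ortho to a large group, gives a 1.2-fold lower number from compound 3 to compound 4 (0.09 log units; within the scatter), the first step that can be read at a single place. Ethoxy is the bigger group by heavy-atom count and, unlike fluoro, is counted as a hydrogen-bond acceptor, yet the two compounds cannot be told apart on this read-out, so this place on the shared core accepts either group with no readable loss of inhibition. No measurement at hand accounts for this outcome, and the step alone cannot show what the place requires of a group.

As far as these compounds go, whether the same holds for a longer chain such as butoxy, or for a group of another kind such as an amine or a carboxylic acid, remains open. Also open, from the compounds shown here alone, is whether plain hydrogen on this carbon would give a number like those of compound 3 and compound 4, which would show whether any group is needed at this place at all.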